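Moving a Nitro Group Around the Ring

This account rests on a few compounds, and the source may have more. Where it says the series, first, only, none or still open, it means among the compounds named here.

Compound 2 `O=C(CSc1nnc(-c2ccncc2)o1)N/N=C/c1ccc([N+](=O)[O-])cc1` gives 195000 nM in an ADME assay on NIH3T3 cells (Mus musculus) for cytotoxicity, read by MTT assay, with a stated time of 24 h (a higher number here means a weaker inhibitor, a lower number a stronger inhibitor), the highest of the two numbers seen so far. Compound 1 `O=C(CSc1nnc(-c2ccncc2)o1)N/N=C/c1ccc(Cl)cc1` gives 181000 nM in this assay, and the step of a 1.1-fold higher number from compound 1 to compound 2 (0.03 log units; within the scatter) shows that swapping the groups on the ring barely moved the number. Compound 3 `O=C(CSc1nnc(-c2ccncc2)o1)N/N=C/c1ccccc1[N+](=O)[O-]` differs from compound 2 by 2-nitrophenyl in place of 4-nitrophenyl on a carbon with a double bond to nitrogen. Among the compounds with values here, no measured step shifts a group around the ring in this way, so the only guide is the small step already seen; no change beyond the scatter is expected, that is a 1.0-fold lower number from compound 2 to compound 3 (0.01 log units; within the scatter). Compound 3 is therefore estimated at 190000 nM, between 100000 nM and 360000 nM.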

Compound 3, half-maximal inhibitory concentration: 214000 nM
Estimate against measurement, compound 3: 1.1-fold (0.05 log units) below, and the stated range covers the measured number.
By their numbers in this assay, from the lowest: compounds 1, 2 and 3 (each within the scatter of the next).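

Moving the nitro group on the ring, with 2-nitrophenyl in place of 4-nitrophenyl, gives a 1.1-fold higher number from compound 2 to compound 3 (0.04 log units; within the scatter) in this assay, so here the two placements cannot be told apart. Putting 2-nitrophenyl in place of 4-chlorophenyl, which changes both the group and where it sits, gives a 1.2-fold higher number from compound 1 to compound 3 (0.07 log units; within the scatter), so this combined change cannot be told apart either. Nothing measured here bears on why these numbers stay so close. Still open, as far as these compounds go, is whether an amine or a carboxylic acid on the ring would move the number beyond the scatter.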